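This account rests on a few compounds, and the source may have more. Where it says the series, first, only, none or still open, it means among the compounds named here.

Measured in a functional assay on C-33-A cells (Homo sapiens) for antiproliferative activity, read by MTT assay; a lower number here means a stronger inhibitor, a higher number a weaker inhibitor:
- compound 1 `Fc1ccc(N2CCN(c3nc(-n4ccc5ccccc54)c4ccccc4n3)CC2)cc1`: 50 ug/mL
- compound 2 `c1ccc2c(c1)ccn2-c1nc(N2CCNCC2)nc2ccccc12`: 8.2 ug/mL
- compound 3 `c1ccc(N2CCN(c3nc(-n4ccc5ccccc54)c4ccccc4n3)CC2)cc1`: 50 ug/mL

Compound 2 has the lowest number of the three, and its steps to both neighbours lie beyond the scatter. The next compound, compound 4 `c1ccc2c(c1)ccn2-c1nc(N2CCCCC2)nc2ccccc12`, has piperidin-1-yl in place of piperazin-1-yl on an aromatic carbon.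

Within the data shown here, no measured compound carries piperidin-1-yl, so the evidence is indirect. The nearest steps concern the amine nitrogen in a ring of compound 2. Phenyl in place of hydrogen there gave a 6.1-fold higher number from compound 2 to compound 3 (0.79 log units; beyond the scatter), and hydrogen in place of 4-fluorophenyl gave a 6.1-fold lower number from compound 1 to compound 2 (0.79 log units; beyond the scatter). Both are modest, and both show the number rising when that hydrogen is replaced. Hydrogen in place of fluoro on an aromatic carbon gave no change at the digits printed from compound 1 to compound 3 (within the scatter), so the two aryl compounds cannot be told apart.

The change to compound 4 adds no aryl group, so a step in the same direction is expected in this assay, though probably a smaller one. The estimate corresponds to a 2.4-fold higher number from compound 2 to compound 4 (0.39 log units; beyond the scatter). Compound 4 is expected near 20 ug/mL, with an estimated range from 7 ug/mL to 55 ug/mL.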

Compound 4, half-maximal inhibitory concentration: 50 ug/mL
Compound 4: the middle estimate sits 2.5-fold (0.40 log units) below what was measured; the range from low to high includes it.
By their numbers in this assay, from the lowest: compound 2; then compounds 1, 3 and 4 (each within the scatter of the next).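

In this assay, the step of a 6.1-fold higher number from compound 2 to compound 4 (0.79 log units; beyond the scatter) comes from a change that keeps the six-membered non-aromatic ring on the aromatic carbon and adds no aryl group: piperidin-1-yl has a carbon where piperazin-1-yl has its second ring nitrogen, with 0 hydrogen-bond donors against 1. The earlier compounds shown here showed the number rising only when an aryl group replaced the hydrogen on that amine nitrogen, yet here the removal of the nitrogen itself gives a step of the same printed size, and compound 3 at 50 ug/mL and compound 4 at 50 ug/mL print the same value. Among these compounds, then, only compound 2, with its unsubstituted piperazin-1-yl, has the lower number, and no measurement on hand explains why the change has this effect.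

The compounds shown leave open whether that ring nitrogen must carry a hydrogen, since a methyl or acetyl group on it would separate the nitrogen from its hydrogen. They also leave open whether a morpholine ring, with oxygen in place of that nitrogen, or an open-chain amine at this position would keep the number of compound 2.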